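The source may hold more compounds than are shown below. What is called first, only, known or untested is meant among the compounds shown, and "the series" means these compounds.

Measured in a functional assay on HT-1080 cells (Homo sapiens) for cytotoxicity, read by MTT assay, with a stated time of 72 h; on this read-out higher numbers stand for weaker inhibition and lower numbers for stronger inhibition:
compound 1, `COc1cc(Nc2nc(C(=N)Nc3ccc(N4CCN(C)CC4)cc3)cc3c(-c4ccccc4)n[nH]c23)cc(OC)c1OC`, gives 3400 nM
compound 2, `CN1CCN(c2ccc(NC(=N)c3cc4c(-c5ccccc5)n[nH]c4c(NC4CCCCC4)n3)cc2)CC1`, gives 650 nM
compound 3, `COc1ccc(Cn2nc(-c3ccccc3)c3cc(C(=N)Nc4ccccc4)nc(NC4CCCCC4)c32)cc1`, gives 3400 nM

Compound 2 and compound 1 share one core and differ in a single place: 3,4,5-trimethoxyphenyl in place of cyclohexyl on a nitrogen on an aromatic ring. In this assay that change gave a 5.2-fold higher number from compound 2 to compound 1 (0.72 log units; beyond the scatter), so compound 1 inhibits the growth of these cells less strongly than compound 2 does.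

Compound 3 is built on a different core, and how its core differs from that of compound 2 is not broken down here. Compound 3 and compound 1 give the same number at the digits shown, and compound 3 gives a higher number than compound 2.

Compound 4, `COc1ccc(Cn2nc(-c3ccccc3)c3cc(C(=N)Nc4ccccc4)nc(Nc4cc(OC)c(OC)c(OC)c4)c32)cc1`, has not yet been measured. It arises from compound 3 by 3,4,5-trimethoxyphenyl in place of cyclohexyl on a nitrogen on an aromatic ring, the same change that turned compound 2 into compound 1, at the same kind of place. Among the measured compounds shown here, from compound 3 to compound 4 a step of a 3.5-fold higher number from compound 3 to compound 4 (0.55 log units; beyond the scatter) is expected because a 5.2-fold higher number from compound 2 to compound 1 (0.72 log units; beyond the scatter) is the only measured instance of this change. Since the cores differ and the earlier step rests on one pair only, the estimate is given with a wide spread. For compound 4 in this assay a value of 12000 nM is expected, between 4000 nM and 40000 nM.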

Compound 4, half-maximal inhibitory concentration: 11100 nM
Compound 4: the middle estimate sits 1.1-fold (0.03 log units) above what was measured, within the range that was stated.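

In this assay, putting 3,4,5-trimethoxyphenyl in place of cyclohexyl on a nitrogen on an aromatic ring gave a 3.3-fold higher number from compound 3 to compound 4 (0.51 log units; beyond the scatter), so this change weakened the effect on these cells on the second core too. Set side by side, the two steps point the same way and do not differ measurably in size: the same change on two cores in this assay, a 5.2-fold higher number (0.72 log units; beyond the scatter) from compound 2 to compound 1 and a 3.3-fold higher number (0.51 log units; beyond the scatter) from compound 3 to compound 4, 1.6-fold (0.20 log units) apart, within the scatter of two such steps. Among the compounds shown here, this shows that, on these two cores, the change carried over in both direction and size, but with only two pairs it does not show that the same would hold on a third core, nor does it explain why the number rises.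

The compounds shown leave open whether a plain phenyl, a phenyl with a single methoxy group or a straight carbon chain on that nitrogen would give a number nearer to that of the cyclohexyl compounds or the 3,4,5-trimethoxyphenyl compounds. They also cannot separate the ways in which the two cores differ, as no pair shown changes only one of those features.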